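A few compounds are considered here, and "the series" means these few. Any claim that something is new, unique, unknown or untested is made for them only; others in the source may bear on it.

In an assay on isolated protein for inhibition of cathepsin S (Homo sapiens), read by fluorescence, with a stated time of 20 min (a lower number here means a stronger inhibitor, a higher number a weaker inhibitor), compound 1 `C[C@@H]1CN(C(=O)[C@@H]2C[C@H](S(=O)(=O)c3ccccc3)C[C@H]2C(=O)NC2(C#N)CC2)C[C@H](C)O1` gives 0.4 nM. In this assay, going by the values given here, compound 2 `N#CC1(NC(=O)[C@@H]2C[C@@H](S(=O)(=O)c3ccccc3)C[C@H]2C(=O)N2CC3CCC(C2)O3)CC1` gives 1 nM, the higher of the two numbers so far, the only measured step being a 2.5-fold higher number from compound 1 to compound 2 (0.40 log units; beyond the scatter), a change made at a carbonyl carbon. Compound 3 `N#CC1(NC(=O)[C@@H]2C[C@@H](S(=O)(=O)c3ccccc3)C[C@H]2C(=O)N2CC3(COC3)C2)CC1` differs from compound 2 by a group of 7 heavy atoms (5 carbon, 1 nitrogen, 1 oxygen; 2 four-membered non-aromatic rings with 1 hetero atom each) in place of a group of 8 heavy atoms (6 carbon, 1 nitrogen, 1 oxygen; one five-membered non-aromatic ring with 1 hetero atom, one six-membered non-aromatic ring with 2 hetero atoms), on a carbonyl carbon. Among the compounds with values here, only that single modest step bears on this change, so at most a small shift, in either direction, or none beyond the scatter is expected in this assay. Compound 3 is estimated at 1.5 nM, within 0.5 nM to 5 nM. That expectation means a step of a 1.5-fold higher number from compound 2 to compound 3 (0.18 log units; within the scatter).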

Compound 3, half-maximal inhibitory concentration: 3 nM
Beside the measured number, compound 3's estimate is 2.0-fold (0.30 log units) below it, and the stated range covers the measured number.
By their numbers in this assay, from the lowest: compound 1; then compound 2; then compound 3.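

In this assay, placing the group with 2 four-membered non-aromatic rings on the carbonyl carbon raises the number again, with a 3.0-fold higher number from compound 2 to compound 3 (0.48 log units; beyond the scatter) and, over the whole series, a 7.5-fold higher number from compound 1 to compound 3 (0.88 log units; beyond the scatter). This position therefore distinguishes among three groups that each contain 1 nitrogen and 1 oxygen, so their ring make-up matters here, not just those atom counts. No measurement shown explains these differences. Still open, going by these compounds, is how this position responds to a piperidine, which has no ring oxygen, or to an open-chain amine such as dimethylamine.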